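Ring Size Change at the Aromatic Nitrogen of Compound 3

The source may hold more compounds than are shown below. What is called first, only, known or untested is meant among the compounds shown, and "the series" means these compounds.

Compound 1 `O=S(=O)(c1cccc(F)c1)c1cn(C2CCNC2)c2ncccc12`: 278 nM in a functional assay on HeLa cells for agonist activity at 5-hydroxytryptamine receptor 6 (Homo sapiens), read by cAMP accumulation and immunoassay; on this read-out higher numbers stand for an effect only at larger amounts of compound and lower numbers for an effect already at smaller amounts
Compound 2 `O=S(=O)(c1cccc(Br)c1)c1cn(C2CCNC2)c2ncccc12`: 35 nM
Compound 3 `O=S(=O)(c1cccc(C(F)(F)F)c1)c1cn(C2CCNC2)c2ncccc12`: 520 nM

Compound 3 gives the highest of the three numbers in this assay. Its nearest neighbour is compound 1, and that gap lies within the scatter; the other gap is a 15-fold higher number from compound 2 to compound 3 (1.17 log units; beyond the scatter) and lies beyond it. Compound 4 `CN1CCCC(n2cc(S(=O)(=O)c3cccc(C(F)(F)F)c3)c3cccnc32)C1` arises from compound 3 by a change in a different part of the molecule: 1-methylpiperidin-3-yl in place of pyrrolidin-3-yl on an aromatic nitrogen. Among the compounds with values here, the measured steps, a 7.9-fold lower number from compound 1 to compound 2 (0.90 log units; beyond the scatter) and a 1.9-fold higher number from compound 1 to compound 3 (0.27 log units; within the scatter), all concern the group on the aromatic carbon, so no step in this set bears on the change at the aromatic nitrogen. Compound 4 is therefore expected to show a 1.2-fold higher number from compound 3 to compound 4 (0.06 log units; within the scatter), with no direction beyond the scatter claimed. The estimate for compound 4 is 600 nM, expected between 150 nM and 2500 nM.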

Compound 4, half-maximal effective concentration: 49 nM
Compound 4: the middle estimate sits 12-fold (1.09 log units) above what was measured, and the stated range ends above it.
By their numbers in this assay, from the lowest: compounds 2 and 4 (each within the scatter of the next); then compounds 1 and 3 (each within the scatter of the next).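

The group on the aromatic nitrogen can also shift the number in this assay, where the earlier steps had shown this only for the group on the aromatic carbon. Replacing pyrrolidin-3-yl with 1-methylpiperidin-3-yl gives an 11-fold lower number from compound 3 to compound 4 (1.03 log units; beyond the scatter), so this position is not silent with trifluoromethyl on the aromatic carbon. No supporting measurement accounts for this step.

The change joins a six-membered ring with a 1-methyl group, leaving open which part matters, as piperidin-3-yl and 1-methylpyrrolidin-3-yl would separate them. On these data alone, whether the same replacement moves the number similarly with bromo or fluoro on the aromatic carbon also remains open.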